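Pyrazole N-substituent swap on a shared core

The source may hold more compounds than are shown below. What is called first, only, known or untested is meant among the compounds shown, and "the series" means these compounds.

Measured so far:
compound 1, `Cc1nn(C2COC2)cc1Nc1nc(N)c2c(C#N)c(N3CCC[C@H]3C)n(C)c2n1`: 240 nM
compound 2, `Cc1nn(CC(C)(C)O)cc1Nc1nc(N)c2c(C#N)c(N3CCC[C@H]3C)n(C)c2n1`: 280 nM
compound 3, `Cc1c(Nc2nc(N)c3c(C#N)c(N4CCC[C@H]4C)n(C)c3n2)cnn1C1COC1`: 300 nM

All three were run in an assay on HEK293 cells for inhibition of Leucine-rich repeat serine/threonine-protein kinase 2 (Homo sapiens), with a stated time of 48 h; on this read-out lower numbers stand for stronger inhibition and higher numbers for weaker inhibition. Compound 1 and compound 2 differ only in the change (2-hydroxy-2-methylpropyl in place of oxetan-3-yl on an aromatic nitrogen), which gave a 1.2-fold higher number from compound 1 to compound 2 (0.07 log units; within the scatter). Compound 1 and compound 3 have the same atoms joined differently: 5-methyl-1-(oxetan-3-yl)-1H-pyrazol-4-yl in place of 3-methyl-1-(oxetan-3-yl)-1H-pyrazol-4-yl on a nitrogen on an aromatic ring, giving a 1.3-fold higher number from compound 1 to compound 3 (0.10 log units; within the scatter). Among the measured compounds shown here, compound 2 and compound 3 have no step counted between them; their two values lie close to each other.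

Compound 4, `Cc1c(Nc2nc(N)c3c(C#N)c(N4CCC[C@H]4C)n(C)c3n2)cnn1CC(C)(C)O`, is not yet measured. It stands to compound 3 as compound 2 stands to compound 1: 2-hydroxy-2-methylpropyl in place of oxetan-3-yl on an aromatic nitrogen. This is the same kind of change, not the same one, since around the place the two differ: in compound 3 the group sits next to the ring atom that bears a methyl group and two ring bonds from the ring atom that bears a large group, whereas in compound 1 it sits two ring bonds from both. Because the earlier step of a 1.2-fold higher number from compound 1 to compound 2 (0.07 log units; within the scatter) stayed within the scatter, the expected step for compound 4 is a 1.2-fold higher number from compound 3 to compound 4 (0.07 log units; within the scatter). Compound 4 is thus estimated at 350 nM, with a range of 200 nM to 600 nM.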

Compound 4, half-maximal inhibitory concentration: 280 nM
Estimate against measurement, compound 4: 1.3-fold (0.10 log units) above; measured number inside the range.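

In this assay the swap of oxetan-3-yl for 2-hydroxy-2-methylpropyl on the aromatic nitrogen gives a 1.1-fold lower number from compound 3 to compound 4 (0.03 log units; within the scatter) and so no step beyond the scatter on this core. Set beside the earlier step, the change reads the same on the core of compound 1 and the core of compound 3: the same change on two cores in this assay, a 1.2-fold higher number (0.07 log units; within the scatter) from compound 1 to compound 2 and a 1.1-fold lower number (0.03 log units; within the scatter) from compound 3 to compound 4, 1.3-fold (0.10 log units) apart, within the scatter of two such steps

Among the compounds shown here, this agreement rests on just two steps, neither of them beyond the scatter, so it shows only that the swap is tolerated on both cores; it does not show that a step of real size would carry from one core to the other, nor does it reach any core beyond these two.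

The compounds shown leave open whether another group on that nitrogen, such as an amine, a carboxylic acid or a longer chain, would give a step beyond the scatter. Equally open, going by these compounds, is whether a step of that size would then carry between the core of compound 1 and the core of compound 3.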